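The source may hold more compounds than are shown below. What is called first, only, known or untested is meant among the compounds shown, and "the series" means these compounds.

So far two compounds built on one shared core have numbers in a functional assay on MCF7 cells (Homo sapiens) for antiproliferative activity, read by MTT assay, with a stated time of 48 h; a lower number here means a stronger inhibitor, a higher number a weaker inhibitor. Compound 1 (`CCn1c(C(=O)NCCN)ccc1C(CC)(CC)c1ccc(OCCC(O)(CC)CC)c(C)c1`) gives 670 nM, and compound 2 (`CCn1c(C(=O)NC(C)C(=O)O)ccc1C(CC)(CC)c1ccc(OCCC(O)(CC)CC)c(C)c1`) gives 19700 nM, the higher of the two numbers and so the weaker inhibitor of this pair. Among the measured compounds shown here, the only measured step is large: a 29-fold higher number from compound 1 to compound 2 (1.47 log units; beyond the scatter), with 1-carboxyethyl in place of 2-aminoethyl on an amide-type nitrogen.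

Compound 3 (`CCn1c(C(=O)N(C)CCO)ccc1C(CC)(CC)c1ccc(OCCC(O)(CC)CC)c(C)c1`) changes the same part of the molecule. Its difference from compound 2 is (2-hydroxyethyl)(methyl)amino in place of (1-carboxyethyl)amino on a carbonyl carbon. The group that entered in a 29-fold higher number from compound 1 to compound 2 (1.47 log units; beyond the scatter) therefore leaves again, but the 2-aminoethyl group does not return. That single step is thin evidence, yet it suggests a partial return towards the lower number, not a full one. The step expected in this assay is a 3.9-fold lower number from compound 2 to compound 3 (0.60 log units; beyond the scatter), an estimated move to a lower number, though a smaller one than the measured step. For compound 3 the estimated value is 5000 nM, with an expected range from 1500 nM to 17000 nM.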

Compound 3, half-maximal inhibitory concentration: 2870 nM
For compound 3 the middle estimate is 1.7-fold (0.24 log units) above the measured one, within the range that was stated.
By their numbers in this assay, from the lowest: compound 1; then compound 3; then compound 2.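

With this assay, the number falls again when the (1-carboxyethyl)amino group is replaced by (2-hydroxyethyl)(methyl)amino on the same carbonyl carbon, giving a 6.9-fold lower number from compound 2 to compound 3 (0.84 log units; beyond the scatter). The recovery is only partial, since the (2-hydroxyethyl)(methyl)amino group still gives a 4.3-fold higher number from compound 1 to compound 3 (0.63 log units; beyond the scatter), so removing the (1-carboxyethyl)amino group does not by itself restore the number seen with the (2-aminoethyl)amino group, which remains the lowest of the three at this position. Nothing measured here explains why the three groups fall in this order.

The step from compound 2 to compound 3 changes several features together, including the loss of the carboxylic acid, the arrival of a hydroxyl and a methyl on the amide nitrogen, so the compounds shown do not separate the contribution of each. As far as these compounds go, a plain 2-hydroxyethyl group without the methyl would bear on that question, and it also remains open whether a longer chain ending in an amine, or a methyl on the nitrogen of the 2-aminoethyl amide, would move the number further from that of compound 1.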